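Swapping a Phenethyl Amide for a Chlorophenyl Amide

The source may hold more compounds than are shown below. What is called first, only, known or untested is meant among the compounds shown, and "the series" means these compounds.

Three compounds share one core and differ only in the group attached to the carbonyl carbon of an amide. Compound 1 `CC(=O)N(C)c1ccc2[nH]c(-c3n[nH]c4ccccc34)cc2n1` gives 23400 nM in a functional assay on SMMC-7721 cells (Homo sapiens) for antiproliferative activity, read by MTT assay, with a stated time of 72 h; a higher number here means a weaker inhibitor, a lower number a stronger inhibitor. Compound 2 `CN(C(=O)C(C)(C)C)c1ccc2[nH]c(-c3n[nH]c4ccccc34)cc2n1` gives 22200 nM in this assay, and compound 3 `CN(C(=O)CCc1ccccc1)c1ccc2[nH]c(-c3n[nH]c4ccccc34)cc2n1` gives 20900 nM. The three numbers sit together: the steps of a 1.1-fold lower number from compound 1 to compound 2 (0.02 log units; within the scatter), a 1.1-fold lower number from compound 1 to compound 3 (0.05 log units; within the scatter) and a 1.1-fold lower number from compound 2 to compound 3 (0.03 log units; within the scatter) all fall within the scatter, so none of the three can be told apart from the others on these figures.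

Compound 4 `CN(C(=O)c1ccc(Cl)cc1)c1ccc2[nH]c(-c3n[nH]c4ccccc34)cc2n1` alters the same position: 4-chlorophenyl in place of phenethyl on a carbonyl carbon. All three measured steps bear on this change, since each swaps the group on the carbonyl carbon, and each stayed within the scatter. Among the measured compounds shown here, no measured compound carries an aromatic group directly on that carbonyl, so the expectation rests on analogy alone. Compound 4 is expected to give about 20000 nM in this assay, with a range from 8000 nM to 50000 nM. The expected step of a 1.0-fold lower number from compound 3 to compound 4 (0.02 log units; within the scatter) is therefore estimated to stay within the scatter.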

Compound 4, half-maximal inhibitory concentration: 2420 nM
The estimate for compound 4 lay 8.3-fold (0.92 log units) above the measured number, and the stated range ends above it.
By their numbers in this assay, from the lowest: compound 4; then compounds 3, 2 and 1 (each within the scatter of the next).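

The group on the carbonyl carbon turns out to matter in this assay: methyl, tert-butyl and phenethyl could not be told apart, yet 4-chlorophenyl stands clear of all three (an 8.6-fold lower number from compound 3 to compound 4 (0.94 log units; beyond the scatter); a 9.2-fold lower number from compound 2 to compound 4 (0.96 log units; beyond the scatter); a 9.7-fold lower number from compound 1 to compound 4 (0.99 log units; beyond the scatter)). Phenethyl also carries a six-membered aromatic ring of carbon only, so having such a ring in the group is not enough for the lower number; compound 4 differs from compound 3 both in losing the saturated chain and in gaining chlorine, and this single step cannot separate the two. Nothing available gives a cause for the drop.

Whether the chlorine or the ring sitting directly on the carbonyl carbon counts for more remains open, as a plain phenyl group on that carbon is not among the compounds shown. Also open, on these data alone, is what happens when an amine or a carboxylic acid takes the place of the chlorine.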